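Halogen pattern on the pendant phenyl and cell toxicity

The compounds below may be only part of what the source reports. "The series", "measured", "known", "first", "only" and "open" are said of these compounds alone.

Two compounds sharing one core have been examined in a toxicity assay on HeLa cells (Homo sapiens) for cytotoxicity; on this read-out lower numbers stand for higher toxicity in this test and higher numbers for lower toxicity in this test. For the measured compounds named here, compound 1 `COc1nc(-c2ccc(Cl)cc2)ccc1[C@@H](c1ccccc1)[C@@](O)(CCN(C)C)c1cccc2ccccc12` is the first. In this assay compound 1 gives > 64 ug/mL, which is a limit of the assay rather than a number. Compound 2 `COc1nc(-c2ccc(C(F)(F)F)cc2)ccc1[C@@H](c1ccccc1)[C@@](O)(CCN(C)C)c1cccc2ccccc12` is the second. In this assay compound 2 gives > 64 ug/mL, again a limit and not a number. The step that the two limits leave unreadable from compound 1 to compound 2 therefore cannot be sized. Compound 2 thus stands at the limit of > 64 ug/mL in this assay, at which 2 of the 2 values shown sit, and no finer placement is possible from what is known.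

Compound 3 `COc1nc(-c2ccc(Cl)c(F)c2)ccc1[C@@H](c1ccccc1)[C@@](O)(CCN(C)C)c1cccc2ccccc12` is the next member, not yet measured. It differs from compound 2 by 4-chloro-3-fluorophenyl in place of 4-(trifluoromethyl)phenyl on an aromatic carbon. Going by the values given here, the only measured step that bears on this change is the one from compound 1 to compound 2, and its size could not be read. No step beyond the usual scatter is expected in this assay for this change. Compound 3 is expected to give about 80 ug/mL, most likely again only as a limit, with a plausible range from 40 ug/mL to 200 ug/mL. The expected step is a step that the limit leaves unreadable from compound 2 to compound 3.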

Compound 3, half-maximal cytotoxic concentration: > 64 ug/mL
Compound 3 gave a limit, no number; the forecaster's own chance of this, stated with the estimate: 80%; the middle value is on the limit's open side.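

Compound 3, like compound 1 and compound 2, gives only a limit of the assay rather than a number in this assay, so no step among these three compounds can be read: the limit of > 64 ug/mL in this assay, at which 3 of the 3 values shown sit. The compounds shown leave open where the actual value of each lies, and whether any of these changes on the pendant phenyl alters toxicity in this test.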